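The compounds below may be only part of what the source reports. "The series", "measured", "known", "first", "only" and "open" are said of these compounds alone.

Measured so far:
compound 1 `O=C(O)Cc1sc(C2COc3ccccc3O2)nc1-c1ccc(Cl)cc1` gives 500 nM in an in vitro assay on HEK385-7 cells for displacement of a labelled ligand from prostaglandin D2 receptor 2 (Homo sapiens); on this read-out lower numbers stand for stronger inhibition and higher numbers for weaker inhibition
compound 2 `O=C(O)Cc1sc(C(c2ccc(F)cc2)c2ccc(F)cc2)nc1-c1ccco1` gives 18 nM in this assay

Of the two numbers, compound 2 stands lowest; compound 1 lies above it by a gap beyond the scatter. Compound 3 `Nc1cc(-c2nc(C(c3ccc(F)cc3)c3ccc(F)cc3)sc2CC(=O)O)cc(F)n1` carries 2-amino-6-fluoropyridin-4-yl in place of furan-2-yl on an aromatic carbon. For the measured compounds named here, no measured pair shows this change, so the size of the step is uncertain. The change is expected to give a step of a 1.4-fold higher number from compound 2 to compound 3 (0.14 log units; within the scatter), close to the scatter and without a clear direction. Compound 3 is estimated at 25 nM, with a range from 8 nM to 80 nM.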

Compound 3, half-maximal inhibitory concentration: 220 nM
Estimate against measurement, compound 3: 8.8-fold (0.94 log units) below; the whole stated range lies below it.
By their numbers in this assay, from the lowest: compound 2; then compound 3; then compound 1.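

Unlike the earlier compounds, which differ in more than one place, this pair isolates the aromatic carbon next to the ring nitrogen, and that position proves sensitive to the group it carries. In this assay the change from furan-2-yl to 2-amino-6-fluoropyridin-4-yl gives a 12-fold higher number from compound 2 to compound 3 (1.09 log units; beyond the scatter) on an otherwise unchanged structure. No available data account for this step.

The compounds shown leave open whether the amine, the fluorine or the six-membered ring itself carries the step. A plain phenyl group at this position would help to separate these.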